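A ring swap from compound 3 to compound 4

The source may report more compounds than this note shows. Statements on the series, on what has been measured and on what is new or still open speak of the compounds shown alone.

Three close relatives share one core. In an in vitro ADME assay on microsomes from Gut (Homo sapiens) for metabolic stability, in the presence of a further agent that is not named here (on this read-out higher numbers stand for fast clearance and lower numbers for slow clearance), compound 1 (`COc1ccc(OC(F)(F)F)cc1Cn1c(C(=O)NCC(C)(C)CO)cc2cc(C#N)ccc21`) gives 68 mL.min-1.g-1 and compound 2 (`COc1ccc(Cl)cc1Cn1c(C(=O)NCC(C)(C)CO)cc2cc(C#N)ccc21`) gives 63 mL.min-1.g-1 while compound 3 (`COc1ccc(C)cc1Cn1c(C(=O)NCC(C)(C)CO)cc2cc(C#N)ccc21`) gives 64 mL.min-1.g-1 and so lies within the scatter of both. Compound 4 (`Cc1ccc(Cl)cc1Cn1c(C(=O)NCC(C)(C)CO)cc2cc(C#N)ccc21`) differs from compound 3 on a saturated chain carbon bound to an aromatic nitrogen (5-chloro-2-methylphenyl in place of 2-methoxy-5-methylphenyl on a saturated chain carbon bound to an aromatic nitrogen). Single swaps on an aromatic carbon all stayed within the scatter (a 1.1-fold lower number from compound 1 to compound 2 (0.03 log units; within the scatter)) (a 1.1-fold lower number from compound 1 to compound 3 (0.03 log units; within the scatter)) (a 1.0-fold higher number from compound 2 to compound 3 (0.01 log units; within the scatter)). Among the compounds with values here, no measured step tests the loss of the methoxy part of 2-methoxy-5-methylphenyl, so the expectation is uncertain. In this assay no change beyond the scatter is expected, and the estimate is a small one (a 1.0-fold higher number from compound 3 to compound 4 (0.01 log units; within the scatter)). For compound 4 the estimated value is 65 mL.min-1.g-1 with an expected range from 35 mL.min-1.g-1 to 120 mL.min-1.g-1 in this measurement.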

Compound 4, intrinsic clearance in microsomes: 124 mL.min-1.g-1
The estimate for compound 4 lay 1.9-fold (0.28 log units) below the measured number; measured number above the stated range.
By their numbers in this assay, from the lowest: compounds 2, 3, 1 and 4 (each within the scatter of the next).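

Within the data shown here, in (this assay), replacing methoxy with methyl on an aromatic carbon gives the first direct reading of that change (a 2.0-fold higher number from compound 2 to compound 4 (0.29 log units; within the scatter)), and the full ring swap gives a step of nearly the same size (a 1.9-fold higher number from compound 3 to compound 4 (0.29 log units; within the scatter)). These are the largest steps in the set and are much larger than the earlier swaps among chloro, methyl and trifluoromethoxy, yet both still lie within the scatter. Nothing shown here accounts for their size.

Going by these compounds, it remains open whether an ethoxy or a hydroxyl group on that aromatic carbon would give a step beyond the scatter.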